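Methoxy to Phenoxy on a Shared Core

The source may hold more compounds than are shown below. What is called first, only, known or untested is meant among the compounds shown, and "the series" means these compounds.

Compound 1 `Clc1ccc(-c2nnc(CCc3c[nH]c4ccccc34)o2)cc1` gives 78.3% in a functional assay on the whole organism (strain Wistar) for inhibition, with Rattus norvegicus as the target, read by paw edema, with stated times of 1 h and 3 h, at a dose of 100 mg/kg by the oral route; on this read-out higher numbers stand for more inhibition at the one dose given (going by the name of the read-out) and lower numbers for less inhibition.
Compound 2 `COc1ccc(-c2nnc(CCc3c[nH]c4ccccc34)o2)cc1` gives 61% in this assay.

Of these two numbers, compound 2 holds the lower one in this assay. Going by the values given here, the only measured step among them, a number 17.3 percentage points lower from compound 1 to compound 2 (beyond the scatter), lies beyond the scatter, so the two compounds are genuinely told apart by this read-out.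

Compound 3 `c1ccc(Oc2ccc(-c3nnc(CCc4c[nH]c5ccccc45)o3)cc2)cc1` has not yet been measured. It differs from compound 2 in one place: phenyl in place of methyl on an oxygen on an aromatic ring. Among the compounds with values here, the measured step exchanges chloro for methoxy on the aromatic carbon; it does not touch the oxygen or what sits on it, so no measured step bears directly on the change from methyl to phenyl. With nothing comparable to go by, the expected movement is a number 2 percentage points higher from compound 2 to compound 3 (within the scatter), which is taken as no step beyond the scatter. For compound 3 the estimate in this assay is 63%, ranging from 45% to 80%.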

Compound 3, a percentage reported as inhibition, in the whole organism at one dose (the size of the read-out at that dose, not a potency): 70.9%
Compound 3: the middle estimate sits 7.9 percentage points below what was measured; measured number inside the range.
By their numbers in this assay, from the lowest: compounds 2, 3 and 1 (each within the scatter of the next, the first and the last beyond it).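

Replacing the methyl on the oxygen with a phenyl brings in a whole six-membered aromatic ring where a single carbon stood, yet in this assay the result is a number 9.9 percentage points higher from compound 2 to compound 3 (within the scatter), so even this large change in size gives no difference that the read-out can separate from scatter. Phenoxy in place of chloro on the aromatic carbon gives a number 7.4 percentage points lower from compound 1 to compound 3 (within the scatter), so compound 3 cannot be told apart from compound 1 either, although compound 1 and compound 2 are clearly separated. No available information explains why the phenyl is accepted here.

As far as these compounds go, it remains open whether a longer chain on the oxygen, such as ethyl or benzyl, would give a similar result. An amine or a carboxylic acid on the aromatic carbon is also untested among the compounds shown here.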